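Replacing a fluorophenoxy arm with a pyrrole ring

A few compounds are considered here, and "the series" means these few. Any claim that something is new, unique, unknown or untested is made for them only; others in the source may bear on it.

Compound 1, `COc1cc(OC)c2c(=O)cc(C(=O)Nc3ccc(Oc4ccc([N+](=O)[O-])cc4)cc3)[nH]c2c1`: in a functional assay on HepG2 cells (Homo sapiens) for antiproliferative activity, with a stated time of 72 h (a higher number here means that more compound is needed for the effect, a lower number that less compound is needed), compound 1 gives > 22900 nM, which is a limit of the assay rather than a number.
Compound 2, `COc1cc(OC)c2c(=O)cc(C(=O)Nc3ccc(Oc4ccc(F)cc4)cc3)[nH]c2c1`: in this assay compound 2 gives > 50000 nM, again a limit and not a number.

Compound 2 thus stands at a limit, as the limit of > 50000 nM in this assay, at which 1 of the 2 values shown sits, shows, and compound 1 likewise sits at a limit, as the limit of > 22900 nM in this assay, at which 1 of the 2 values shown sits, shows. For the measured compounds named here, the only measured step, a step that the two limits leave unreadable from compound 1 to compound 2, runs between two limits and its size cannot be read. Compound 3, `COc1cc(OC)c2c(=O)cc(C(=O)Nc3ccc(-n4cccc4)cc3)[nH]c2c1`, differs from compound 2 by 1H-pyrrol-1-yl in place of 4-fluorophenoxy on an aromatic carbon. Going by the values given here, no measured step bears directly on this change; the one step available is unreadable. The expectation for compound 3 in this assay rests on the limit seen for compound 2 alone: most likely compound 3 also returns only a limit, though a measurable number cannot be excluded. The expected step of an at least 1.6-fold lower number from compound 2 to compound 3 (0.22 log units; that floor lies within the scatter) is estimated to be small or itself unreadable. Compound 3 is estimated at 30000 nM, with a range from 5000 nM to 100000 nM.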

Compound 3, half-maximal effective concentration: > 77000 nM
Compound 3 ended at the assay's limit; the forecaster's own chance of this, stated with the estimate: 60%; middle value at least 2.5-fold (0.40 log units) from the limit.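

No new step can be read among compound 1, compound 2 and compound 3: in this assay each gives only a limit of the assay, not a number. The compounds shown leave open whether exchanging 4-nitrophenoxy, 4-fluorophenoxy and 1H-pyrrol-1-yl on the shared core changes how much compound is needed for the effect.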